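The source may report more compounds than this note shows. Statements on the series, on what has been measured and on what is new or still open speak of the compounds shown alone.

Measured so far:
compound 1, `Cc1ccccc1S(=O)(=O)c1ccc(CNC(=O)c2cc3cnccc3[nH]2)cc1`, 15%
compound 2, `O=C(NCc1ccc(S(=O)(=O)c2cccc(C(F)(F)F)c2)cc1)c1cc2ccncc2o1`, 64%

In an ADME assay on microsomes from liver (Mus musculus) for metabolic stability, read by LC-MS, with a stated time of 30 min, tested at 1 uM (on this read-out lower numbers stand for a less stable compound and higher numbers for a more stable compound), compound 1 gives 15%, the lower of the two numbers recorded. Going by the values given here, compound 2 gives 64%, a number well beyond the scatter above it; the two compounds differ in more than one place, so no single step connects them.

Compound 3, `O=C(NCc1ccc(S(=O)(=O)c2ccccc2)cc1)c1cc2cnccc2[nH]1`, has not yet been measured. It differs from compound 1 in one place: hydrogen in place of methyl on an aromatic carbon. The two-carbon chain and the shared core are unchanged.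

Among the compounds with values here, no measured pair shows this change on its own, so its effect is unknown. Compound 3 is expected to stand close to compound 1, with an estimated step of a number 7 percentage points higher from compound 1 to compound 3 (within the scatter), most likely within the scatter or slightly upward. For compound 3 the expected value is 22%, in a range from 8% to 42%.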

Compound 3, percent of the compound remaining: 54%
Estimate against measurement, compound 3: 32 percentage points below; the measured number lies above the stated range.
By their numbers in this assay, from the lowest: compound 1; then compounds 3 and 2 (each within the scatter of the next).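

In this assay the change from 2-methylphenyl to phenyl gives a number 39 percentage points higher from compound 1 to compound 3 (beyond the scatter) and so marks this single methyl, ortho to a large group, as a place where the read-out can move strongly. Compound 1 and compound 2 differ in more than one place, and their gap points to no single group, whereas this pair isolates one small change on a six-membered aromatic ring of carbon only. Nothing available explains why losing this one carbon goes with a step of this size.

The compounds shown hold no methoxy group or chlorine at this place, so it stays open whether other groups there would behave like the methyl or like hydrogen. As far as these compounds go, it also stays open whether the same change would give a similar step on the core of compound 2.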